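A few compounds are considered here, and "the series" means these few. Any claim that something is new, unique, unknown or untested is made for them only; others in the source may bear on it.

Measured so far in a functional assay on HEK293 cells with D(4) dopamine receptor (Homo sapiens) as the target, read by FLIPR; a higher number here means that more compound is needed for the effect, a lower number that less compound is needed:
compound 1 `CCO/N=C(\CCN1CCN(c2ccccc2C#N)CC1)c1ccccc1`: 48.7 nM
compound 2 `CCO/N=C(\CCN1CCN(c2cccc(OCC)c2)CC1)c1ccccc1`: 347 nM

Going by the values given here, compound 2 stands at the highest of the two numbers; the only step here, a 7.1-fold higher number from compound 1 to compound 2 (0.85 log units; beyond the scatter), was modest but beyond the scatter.

Compound 3 `CCO/N=C(\CCN1CCN(c2ncccc2C)CC1)c1ccccc1` is not yet measured. It differs from compound 2 by 3-methylpyridin-2-yl in place of 3-ethoxyphenyl on an amine nitrogen in a ring. Among the compounds with values here, only the step from compound 1 to compound 2 bears on it, as it changes the same aryl group on the same ring nitrogen. That step was beyond the scatter, so a change of similar size is expected, and the number for compound 3 is expected to move back toward compound 1, giving a 3.2-fold lower number from compound 2 to compound 3 (0.50 log units; beyond the scatter). The expected value for compound 3 is 110 nM, range 35 nM to 350 nM.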

Compound 3, half-maximal effective concentration: 253 nM
Estimate against measurement, compound 3: 2.3-fold (0.36 log units) below; low and high end bracket the measured number.
By their numbers in this assay, from the lowest: compound 1; then compounds 3 and 2 (each within the scatter of the next).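

In this assay, replacing the aryl group on the amine nitrogen in the ring gives (a 1.4-fold lower number from compound 2 to compound 3 (0.14 log units; within the scatter)), so 3-methylpyridin-2-yl and 3-ethoxyphenyl are not separated at this position, even with a ring nitrogen entering. The comparison with 2-cyanophenyl gives (a 5.2-fold higher number from compound 1 to compound 3 (0.72 log units; beyond the scatter)), leaving compound 1 alone at the low end of the three. Nothing on hand accounts for this.

Going by these compounds, compounds 1 and 3 differ in both ring atoms and ring group, so the contribution of the nitrile remains open. An unsubstituted phenyl or a chlorophenyl at this position would help separate these contributions.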